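The source may hold more compounds than are shown below. What is called first, only, known or untested is meant among the compounds shown, and "the series" means these compounds.

Measured so far:
compound 1 `COc1cccc(OC)c1OCCNCCOc1ccccc1OCc1ccccc1Cl`, 0.251 nM
compound 2 `COc1cccc(OC)c1OCCNCCOc1ccccc1OCc1ccccc1C`, 0.126 nM

In an assay on CHO cells for displacement of a labelled ligand from Alpha-1D adrenergic receptor (Homo sapiens) (on this read-out higher numbers stand for weaker inhibition and lower numbers for stronger inhibition), compound 1 gives 0.251 nM and compound 2 gives 0.126 nM. Compound 2 has the lower of the two numbers, yet the step of a 2.0-fold lower number from compound 1 to compound 2 (0.30 log units; within the scatter) stays within the scatter, so the pair stands level. Compound 3 `COc1cccc(OC)c1OCCNCCOc1ccccc1OCc1cccc([N+](=O)[O-])c1` is not yet measured; it differs from compound 2 by 3-nitrophenyl in place of 2-methylphenyl on a saturated chain carbon bound to an oxygen on an aromatic ring. Among the measured compounds shown here, the only measured step concerns a different exchange and bears only loosely on this larger one. For the measured compounds named here, with no close precedent, a modest move toward a higher number is expected, a 3.2-fold higher number from compound 2 to compound 3 (0.50 log units; beyond the scatter). Compound 3 is estimated at 0.4 nM, ranging from 0.1 nM to 1.6 nM.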

Compound 3, inhibition constant: 0.0631 nM
Estimate against measurement, compound 3: 6.3-fold (0.80 log units) above; the whole stated range lies above it.
By their numbers in this assay, from the lowest: compounds 3, 2 and 1 (each within the scatter of the next, the first and the last beyond it).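

In this assay this place on the saturated chain carbon bound to an oxygen on an aromatic ring accepts 3-nitrophenyl, with 9 heavy atoms and 2 hydrogen-bond acceptors, as well as 2-methylphenyl, with 7 heavy atoms and none: a 2.0-fold lower number from compound 2 to compound 3 (0.30 log units; within the scatter) leaves the pair level. Among the compounds shown here, the exchange against 2-chlorophenyl gives a 4.0-fold lower number from compound 1 to compound 3 (0.60 log units; beyond the scatter) and is the first step to pass the scatter, though only modestly.

On these data alone, how an amine or a carboxylic acid in place of the nitro group would read stays open. Nothing measured here accounts for these numbers.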